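The compounds below may be only part of what the source reports. "The series", "measured", "known", "first", "only" and "open" are said of these compounds alone.

Compound 1 `CCCCCCCC(CCO)n1cnc2c(OC)ncnc21`: 23900 nM
Compound 2 `CCCCCCCC(CCO)n1cnc2c(NC)ncnc21`: 15300 nM
Compound 3 `CCCCCCCCCC(CCO)n1cnc2c(OC)ncnc21`: 3250 nM

All three numbers come from a functional assay on SW480 cells (Homo sapiens) for antiproliferative activity, read by MTT assay, with a stated time of 48 h; on this read-out lower numbers stand for stronger inhibition and higher numbers for weaker inhibition. Compound 3 carries the lowest number of the set; the step from compound 1 to compound 3 is a 7.4-fold lower number from compound 1 to compound 3 (0.87 log units; beyond the scatter), and the difference between these two cores is ethyl in place of hydrogen on a saturated chain carbon, eight bonds along the chain from an aromatic nitrogen. Compound 4 `CCCCCCCCCC(CCO)n1cnc2c(NC)ncnc21` has not yet been measured in this assay. It differs from compound 3 by methylamino in place of methoxy on an aromatic carbon, which is the same change, on the same place word for word, as methylamino in place of methoxy on an aromatic carbon; that earlier step was a 1.6-fold lower number from compound 1 to compound 2 (0.19 log units; within the scatter). Within the data shown here, for compound 4 a step of comparable size is expected, a 1.5-fold lower number from compound 3 to compound 4 (0.17 log units; within the scatter), because the only prior example of this change gave a 1.6-fold lower number from compound 1 to compound 2 (0.19 log units; within the scatter). Compound 4 is therefore estimated at 2200 nM, with a plausible range from 900 nM to 5500 nM.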

Compound 4, half-maximal inhibitory concentration: 4450 nM
Compound 4: the middle estimate sits 2.0-fold (0.31 log units) below what was measured; measured number inside the range.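

In this assay, methylamino in place of methoxy on the longer-chain core gives a 1.4-fold higher number from compound 3 to compound 4 (0.14 log units; within the scatter), and the change stays small on both cores, with no detectable difference between them: the same change on two cores in this assay, a 1.6-fold lower number (0.19 log units; within the scatter) from compound 1 to compound 2 and a 1.4-fold higher number (0.14 log units; within the scatter) from compound 3 to compound 4, 2.1-fold (0.33 log units) apart, within the scatter of two such steps. Ethyl in place of hydrogen on the saturated chain also carries over, giving a 3.4-fold lower number from compound 2 to compound 4 (0.54 log units; beyond the scatter) on the methylamino core: the same change on two cores in this assay, a 7.4-fold lower number (0.87 log units; beyond the scatter) from compound 1 to compound 3 and a 3.4-fold lower number (0.54 log units; beyond the scatter) from compound 2 to compound 4, 2.1-fold (0.33 log units) apart, within the scatter of two such steps. Among these compounds, this rests on only two pairs of cores and does not show that either change would behave the same way on any other core, nor that methoxy and methylamino differ at all in this assay.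

The compounds shown leave open what a dimethylamino group or a free amine would do on that aromatic carbon. They also leave open whether a still longer chain would lower the number further, and what a carboxylic acid would do in place of the chain hydroxyl.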